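A Methyl on the Saturated Ring: Expected Growth Inhibition

The source may report more compounds than this note shows. Statements on the series, on what has been measured and on what is new or still open speak of the compounds shown alone.

Compound 1 `Cc1nc(Nc2ccc3sc(C(=O)Nc4c(C)cccc4Cl)cc3c2)cc(N2CCCCC2)n1`: 20.6%
Compound 2 `CCN(CC)CCCOc1cc2ncnc(Nc3ccc4sc(C(=O)Nc5c(C)cccc5Cl)cc4c3)c2cc1OC`: 78%

Both measured compounds were tested in a functional assay on U-937 cells (Homo sapiens) for inhibition, read by MTT assay and WST assay, with a stated time of 72 h, tested at 10 uM; on this read-out lower numbers stand for less inhibition of growth and higher numbers for more inhibition of growth at the one concentration tested. Compound 1 gives 20.6%, the lower of the two numbers. Compound 2 gives 78%, a number far higher and well beyond the scatter. Within the data shown here, these two compounds differ in many places at once, so no single step between them is counted; their values show only that compound 2 inhibits growth much more than compound 1 at this one concentration.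

Compound 3 `Cc1nc(Nc2ccc3sc(C(=O)Nc4c(C)cccc4Cl)cc3c2)cc(N2CCC(C)CC2)n1` has not yet been measured. It differs from compound 1 by methyl in place of hydrogen on a saturated ring carbon, three ring bonds from the ring nitrogen. One carbon enters, with no ring, no donors, no acceptors and no charge. Among the measured compounds shown here, no measured pair shows what such a change does here, so the expectation rests on compound 1 alone. The expected step from compound 1 to compound 3 is a number 3.4 percentage points higher from compound 1 to compound 3 (within the scatter), none beyond the scatter in either direction. Compound 3 is estimated at 24%, with a range from 8% to 45%.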

Compound 3, percent growth inhibition at one concentration: 24.6%
Compound 3: middle estimate off by 0.6 percentage points, on the low side; the measured number falls inside the stated range.
By their numbers in this assay, from the lowest: compounds 1 and 3 (each within the scatter of the next); then compound 2.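

In this assay, the change from piperidin-1-yl to 4-methylpiperidin-1-yl comes to a number 4 percentage points higher from compound 1 to compound 3 (within the scatter). Among these compounds, this is the only single-place comparison available so far, and it shows that a methyl in place of hydrogen on this saturated ring carbon, three ring bonds from the ring nitrogen, gives no difference that can be told apart from the usual scatter of repeated measurements at the one concentration tested. Nothing measured here explains why this step is so small, and the finding rests on this one pair.

As far as these compounds go, it remains open whether another group on the same ring carbon, such as a hydroxyl, an amine, a carboxylic acid or a longer chain such as propyl, would produce a step beyond the scatter. From the compounds shown here alone, it is also open whether the same methyl would give a similar result on a different carbon of this ring, or whether replacing the whole ring with another amine would matter more.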